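Cyclopropyl in place of isobutyl: compound 3 to compound 4

The compounds below may be only part of what the source reports. "The series", "measured", "known", "first", "only" and "open" are said of these compounds alone.

Of the compounds shown here, three sharing one core have been measured in an ADME assay on a cell-free system (plasma, Rattus norvegicus), with a stated time of 60 min; a lower number here means that less of the compound is left, a higher number that more of the compound is left. Compound 1 (`O=C(O)c1cc(-c2cccc(COc3ccc4c(c3)CN(c3ccccc3)C4=O)c2)ccc1Cl`) gives 100%, compound 2 (`O=C(O)c1cc(-c2cccc(COc3ccc4c(c3)CN(C3CCC3)C4=O)c2)ccc1Cl`) gives 100%, and compound 3 (`CC(C)CN1Cc2cc(OCc3cccc(-c4ccc(Cl)c(C(=O)O)c4)c3)ccc2C1=O`) gives 99%. Compound 3 therefore stands level with the other two within the scatter.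

Compound 4 (`O=C(O)c1cc(-c2cccc(COc3ccc4c(c3)CN(C3CC3)C4=O)c2)ccc1Cl`) has not yet been measured. It carries cyclopropyl in place of isobutyl on an amide-type nitrogen in a ring.

Going by the values given here, three measured steps bear on this change, as all of them fall at the same place: no change at the digits printed from compound 1 to compound 2 (within the scatter), a number 1 percentage points lower from compound 1 to compound 3 (within the scatter) and a number 1 percentage points lower from compound 2 to compound 3 (within the scatter). Each stays within the scatter, across phenyl, cyclobutyl and isobutyl alike. No step beyond the scatter is therefore expected in this assay, and the expected step is no change at the digits printed from compound 3 to compound 4 (within the scatter). In this assay the estimate for compound 4 is 99%, with an expected range from 91% to 100%.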

Compound 4, percent of the compound remaining: 100%
For compound 4 the middle estimate is 1 percentage points below the measured one; the measured number falls inside the stated range.
By their numbers in this assay, from the lowest: compounds 3, 1, 2 and 4 (each within the scatter of the next).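

In this assay, cyclopropyl, the group with the fewest heavy atoms yet placed on this amide-type nitrogen in a ring, leaves the read-out level with the other groups: a number 1 percentage points higher from compound 3 to compound 4 (within the scatter), no change at the digits printed from compound 2 to compound 4 (within the scatter) and no change at the digits printed from compound 1 to compound 4 (within the scatter). Across compound 1, compound 2, compound 3 and compound 4, the phenyl, cyclobutyl, isobutyl and cyclopropyl groups thus give no step beyond the scatter, and none of these compounds goes against that. Nothing available explains why this position tolerates these changes in this assay.

Going by these compounds, all four groups consist of carbon only, so it remains open whether an amine or a hydroxyalkyl chain on this nitrogen would also stay level. Also open, on these data alone, is whether an ester in place of the carboxylic acid on the shared core would leave the read-out unchanged.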